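The compounds below may be only part of what the source reports. "The series", "measured", "known", "first", "only" and "open" are said of these compounds alone.

Three compounds of this series have been run through an assay on Sf9 cells for inhibition of protein deacetylase HDAC6 (Homo sapiens), read by fluorescence, with a stated time of 40 min, tested at 100 nM (on this read-out higher numbers stand for more inhibition at the one concentration tested (going by the name of the read-out) and lower numbers for less inhibition), so far. Compound 1 `COc1ccc(-n2nc(-c3ccc(O)cc3)nc2CNc2ccc(C(=O)NO)cc2)cc1` gives 70.3%. Compound 2 `O=C(NO)c1ccc(NCc2nc(-c3ccccc3)nn2-c2ccc(F)cc2)cc1` gives 67.6%. Compound 3 `O=C(O)c1ccc(NCc2nc(-c3ccccc3)nn2-c2ccccc2)cc1` gives -0.4%. On these three numbers compound 2 stands second highest: its nearest neighbour is compound 1, whose number lies slightly higher but within the scatter, so no order between the two can be read; its furthest neighbour is compound 3, whose number lies far lower and beyond the scatter. Going by the values given here, compounds 1 and 2 both carry a hydroxamic acid, compound 3 a carboxylic acid; no step between measured compounds that differ in a single place exists, so nothing more than the two values themselves can be said of that gap.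

Compound 4 `Cc1ccc(-n2nc(-c3ccccc3)nc2CNc2ccc(C(=O)NO)cc2)cc1C` awaits measurement in this assay . It differs from compound 2 in one place: 3,4-dimethylphenyl in place of 4-fluorophenyl on an aromatic nitrogen. The hydroxamic acid and the remainder of the shared core stay as in compound 2. Among the compounds with values here, the data hold no step of this kind, but compounds 1 and 2, which differ from each other in more than one place and both keep the hydroxamic acid, sit within the scatter of each other. The step from compound 2 to compound 4 is therefore expected to be small, a number 2.6 percentage points lower from compound 2 to compound 4 (within the scatter), and not beyond the scatter. Compound 4 is estimated at 65%, with a range from 45% to 80%.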

Compound 4, a percentage reported as inhibition, at one concentration (the size of the read-out at that concentration, not a potency): 53%
Estimate against measurement, compound 4: 12 percentage points above; low and high end bracket the measured number.
By their numbers in this assay, from the lowest: compound 3; then compound 4; then compounds 2 and 1 (each within the scatter of the next).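

In this assay, going by these compounds alone, the earlier compounds held no step in a single place, so this is the first direct reading of the aryl group on the aromatic nitrogen: 3,4-dimethylphenyl in place of 4-fluorophenyl gives a number 14.6 percentage points lower from compound 2 to compound 4 (beyond the scatter), with the hydroxamic acid and the rest of the shared core unchanged. The position is therefore not neutral on this read-out, and a change to this aryl group alone can move the number beyond the scatter, although compound 4 still gives 53% and so retains a sizeable inhibition. Nothing at hand accounts for the size or direction of this step.

This single step swaps one fluorine for two methyl groups, so the compounds shown do not separate the loss of the fluorine from the entry of either methyl group. A 4-methylphenyl or a 4-chlorophenyl at this position on the same core would begin to separate these, while a cyclohexyl group would test whether an aromatic ring is needed here at all.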